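Fluorinated aryl swap on the saturated ring carbon

The compounds below may be only part of what the source reports. "The series", "measured", "known", "first", "only" and "open" are said of these compounds alone.

Compound 3 `COc1cc(C2=NN(C(C)=O)C(c3ccc(C(F)(F)F)cc3)O2)cc(OC)c1OC` stands lowest of the three numbers in a functional assay on BGC-823 cells (Homo sapiens) for antiproliferative activity, read by MTT assay, tested at 5 uM (on this read-out lower numbers stand for a weaker effect and higher numbers for a stronger effect at the one concentration tested), with 3.4%. Compound 1 `COc1cc(C2=NN(C(C)=O)C(c3c(Cl)cccc3Cl)O2)cc(OC)c1OC` gives 15.9% and compound 2 `COc1ccc(OC)c(C2OC(c3cc(OC)c(OC)c(OC)c3)=NN2C(C)=O)c1` gives 18.2%; the two sit within the usual scatter of each other, as the step of a number 2.3 percentage points higher from compound 1 to compound 2 (within the scatter) shows. Going by the values given here, both steps toward compound 3 are beyond the scatter: a number 12.5 percentage points lower from compound 1 to compound 3 (beyond the scatter) and a number 14.8 percentage points lower from compound 2 to compound 3 (beyond the scatter), so the 4-(trifluoromethyl)phenyl group marks the weak end of the series so far.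

Compound 4 `COc1cc(C2=NN(C(C)=O)C(c3ccc(F)c(F)c3)O2)cc(OC)c1OC` carries the following change against compound 3: 3,4-difluorophenyl in place of 4-(trifluoromethyl)phenyl on a saturated ring carbon. Among the compounds with values here, no measured step covers this particular exchange, so the only guidance is that each aryl replacement at this saturated ring carbon so far moved the read-out by a modest amount or not beyond the scatter. Compound 4 is therefore expected to give 10% in this assay, with a plausible range of 0% to 22%. This estimate means a step of a number 6.6 percentage points higher from compound 3 to compound 4 (within the scatter), which is expected to fall within the scatter or only slightly beyond it.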

Compound 4, a percentage reported as inhibition, at one concentration (the size of the read-out at that concentration, not a potency): 21.6%
The estimate for compound 4 lay 11.6 percentage points below the measured number; the range from low to high includes it.
By their numbers in this assay, from the lowest: compound 3; then compounds 1, 2 and 4 (each within the scatter of the next).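

In this assay, the result shows that a fluorinated aryl group on this saturated ring carbon is not weak as such: 3,4-difluorophenyl in place of 4-(trifluoromethyl)phenyl gives a number 18.2 percentage points higher from compound 3 to compound 4 (beyond the scatter). The other two new steps, a number 3.4 percentage points higher from compound 2 to compound 4 (within the scatter) and a number 5.7 percentage points higher from compound 1 to compound 4 (within the scatter), leave 3,4-difluorophenyl, 2,5-dimethoxyphenyl and 2,6-dichlorophenyl without any order among them, so compound 3 alone stands apart as the weakest of the four. Nothing at hand explains why the 4-(trifluoromethyl)phenyl group parts from the other three.

The compounds shown leave open how a single 4-fluorophenyl group would compare with these aryl groups. Also open, as far as these compounds go, is whether a carboxylic acid or an amine on the aryl ring, or a longer alkyl chain in place of the aryl group, would hold the read-out at this carbon.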